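Replacing methanesulfonamido on the shared core of compound 1

The source may report more compounds than this note shows. Statements on the series, on what has been measured and on what is new or still open speak of the compounds shown alone.

Measured so far in a functional assay on CHO cells for agonist activity at Alpha-1A adrenergic receptor (Homo sapiens), read by FLIPR and calcium flux; a higher number here means a larger maximal response, a lower number a smaller maximal response:
compound 1 `CS(=O)(=O)Nc1cccc2c1CCC2c1ncc[nH]1` gives 87%
compound 2 `Cc1oncc1-c1cccc2c1CCC2c1ncc[nH]1` gives 63%
compound 3 `COc1cccc2c1CCC2c1ncc[nH]1` gives 65%

Compound 1 stands highest of the three numbers; the steps away from it are a number 22 percentage points lower from compound 1 to compound 3 (beyond the scatter) and a number 24 percentage points lower from compound 1 to compound 2 (beyond the scatter). Between the two lower compounds there is a number 2 percentage points higher from compound 2 to compound 3 (within the scatter).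

Compound 4 `Cn1nccc1-c1cccc2c1CCC2c1ncc[nH]1` is not yet measured. It differs from compound 1 thus: 1-methyl-1H-pyrazol-5-yl in place of methanesulfonamido on an aromatic carbon. The step that bears most on it is the one in which another five-membered aromatic ring with two hetero atoms took the place of methanesulfonamido, a number 24 percentage points lower from compound 1 to compound 2 (beyond the scatter); the step of a number 22 percentage points lower from compound 1 to compound 3 (beyond the scatter) points the same way. A modest drop in this assay is therefore expected, about a number 24 percentage points lower from compound 1 to compound 4 (beyond the scatter). Compound 4 is estimated at 63%, with a range from 48% to 78%.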

Compound 4, largest response reached (Emax), in percent of the reference or control that the assay uses: 58%
For compound 4 the middle estimate is 5 percentage points above the measured one; the range from low to high includes it.
By their numbers in this assay, from the lowest: compounds 4, 2 and 3 (each within the scatter of the next); then compound 1.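

In this assay, the 1-methyl-1H-pyrazol-5-yl group gives a number 29 percentage points lower from compound 1 to compound 4 (beyond the scatter), so a third replacement of methanesulfonamido on this aromatic carbon also falls short of compound 1. The replacements themselves separate little: the exchange of one five-membered aromatic ring for the other gives a number 5 percentage points lower from compound 2 to compound 4 (within the scatter), and the exchange of methoxy for the ring gives a number 7 percentage points lower from compound 3 to compound 4 (within the scatter). Nothing measured here accounts for these differences. The compounds shown do not separate the hydrogen-bond donor of methanesulfonamido from the rest of that group. From the compounds shown here alone, whether an amine or an acetamido group at this carbon would match compound 1 remains open.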